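A few compounds are considered here, and "the series" means these few. Any claim that something is new, unique, unknown or untested is made for them only; others in the source may bear on it.

Compound 1, drawn as `COC(=O)c1nnn([C@@H]2C(=O)N(c3ccc(C)cc3)[C@@H]2/C=C/c2ccccc2)c1C(=O)OC`, carries a shared core that also appears in a second compound, compound 2, drawn as `O=C1[C@@H](n2cc(-c3ccccc3)nn2)[C@@H](/C=C/c2ccccc2)N1C1CCCCC1`. In a functional assay on KB cells (Homo sapiens) for inhibition, tested at 100 uM (on this read-out higher numbers stand for more inhibition of growth at the one concentration tested and lower numbers for less inhibition of growth), compound 1 gives "not determined" (no result reported), so there is no single number that fixes where it stands. In this assay compound 2 gives 99.7%, which is close to complete inhibition of growth at the one concentration tested. Compound 2 is not a one-place neighbour of compound 1, so its result only shows what this kind of core can reach and not how compound 1 itself behaves.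

Compound 3, drawn as `COC(=O)c1nnn([C@@H]2C(=O)N(c3ccc(Cl)cc3)[C@@H]2/C=C/c2ccccc2)c1C(=O)OC`, differs from compound 1 in one place: chloro in place of methyl on an aromatic carbon. Going by the values given here, no measured pair with this change is available, so the size and direction of the step cannot be read from the data, and the expectation rests on compound 2 alone as the only number in hand. On that basis compound 3 is expected to give about 70% in this assay, somewhere between 20% and 100%.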

Compound 3, percent growth inhibition at one concentration: 56.5%
Beside the measured number, compound 3's estimate is 13.5 percentage points above it; the measured number falls inside the stated range.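

In this assay compound 3 gives 56.5% while compound 1 has no single number, so no step can be read between compound 1 and compound 3. The compounds shown leave open how far going from 4-methylphenyl to 4-chlorophenyl moves growth inhibition, and in which direction. Nothing at hand offers an explanation for the result of compound 3.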